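The source may report more compounds than this note shows. Statements on the series, on what has been measured and on what is new or still open speak of the compounds shown alone.

In a functional assay on MCF7 cells (Homo sapiens) for antiproliferative activity, read by CCK-8 assay, with a stated time of 48 h (a lower number here means a stronger inhibitor, a higher number a weaker inhibitor), compound 1 `O=C(/C=C/CNCCOc1ccc(Oc2c(-c3ccc(F)cc3)sc3cc(O)ccc23)cc1)N1CCCC1` gives 7610 nM and compound 2 `C/C=C/C(=O)N1CC(Oc2ccc(Oc3c(-c4ccc(F)cc4)sc4cc(O)ccc34)cc2)C1` gives 28000 nM. Compound 3 `O=C(/C=C/CN1CC(Oc2ccc(Oc3c(-c4ccc(F)cc4)sc4cc(O)ccc34)cc2)C1)N1CCC1` stands at > 25000 nM, which is a limit of the assay and not a number. This is the limit of > 25000 nM in this assay, at which 1 of the 3 values shown sits.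

The next change leads to compound 4 `C=C(C)C(=O)N1CC(Oc2ccc(Oc3c(-c4ccc(F)cc4)sc4cc(O)ccc34)cc2)C1`: (1-methylethenyl)carbonyl in place of 3-((azetidin-1-yl)carbonyl)prop-2-en-1-yl on an amine nitrogen in a ring. In words, (1-methylethenyl)carbonyl comes in place of 3-((azetidin-1-yl)carbonyl)prop-2-en-1-yl on an amine nitrogen in a ring.

For the measured compounds named here, only one measured step touches this place, a step that the limit leaves unreadable from compound 2 to compound 3, so it offers no size to carry over. The nearest guide is compound 2 at 28000 nM, which has (prop-1-en-1-yl)carbonyl on that same nitrogen and is therefore expected to resemble compound 4. No step beyond the scatter is expected in this assay, and no direction can be assigned. The expected step is a number no higher from compound 3 to compound 4 (the limit leaves the size open), and compound 4 may also end up reported only as a limit.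

For compound 4 the estimated value is 25000 nM, with an expected range of 12000 nM to 50000 nM.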

Compound 4, half-maximal inhibitory concentration: > 25000 nM
Compound 4: no number, only a limit; the forecaster's own chance of this, stated with the estimate: 45%; the middle value sits exactly at the limit.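

Compound 4 gives > 25000 nM in this assay, a limit of the assay and not a number, so no new step can be read from compound 2 or compound 3 to compound 4. The compounds shown leave open whether (1-methylethenyl)carbonyl, (prop-1-en-1-yl)carbonyl and 3-((azetidin-1-yl)carbonyl)prop-2-en-1-yl on that ring nitrogen differ at all.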